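The source may hold more compounds than are shown below. What is called first, only, known or untested is meant among the compounds shown, and "the series" means these compounds.

In a functional assay on HFF cells (Homo sapiens) for cytotoxicity (a lower number here means that less compound is tolerated, a higher number that more compound is tolerated), three compounds built on one shared core have been measured. Compound 1 (`Nc1nc(OCC2CC2)c2ncn(/C=C3/C[C@@H]3CO)c2n1`) gives 112000 nM, compound 2 (`CCCCCOc1nc(N)nc2c1ncn2/C=C1/C[C@@H]1CO`) gives 41900 nM, and compound 3 (`COc1nc(N)nc2c1ncn2/C=C1/C[C@@H]1CO`) gives 15800 nM, the lowest of the three numbers. Compound 4 (`CCCOc1nc(N)nc2c1ncn2/C=C1/C[C@@H]1CO`) has not yet been measured. Its difference from compound 3 is ethyl in place of hydrogen on a saturated chain carbon bound to an oxygen on an aromatic ring, which turns methoxy into propoxy.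

Two measured steps change the same place and end at compound 3: a 2.7-fold lower number from compound 2 to compound 3 (0.42 log units; beyond the scatter), where hydrogen replaces butyl, and a 7.1-fold lower number from compound 1 to compound 3 (0.85 log units; beyond the scatter), where hydrogen replaces cyclopropyl. Both are modest and beyond the scatter, and both show compound 3 with the lower number. A third step, a 2.7-fold lower number from compound 1 to compound 2 (0.43 log units; beyond the scatter), separates the two larger groups, so the number does not depend on the mere presence of a larger group alone. Ethyl is a shorter addition than butyl, so the butyl step serves as the closest guide and as a rough upper size. The expected step is a small rise near the edge of the scatter, a 1.9-fold higher number from compound 3 to compound 4 (0.28 log units; within the scatter). For compound 4 the estimated value is 30000 nM, with an expected range from 14000 nM to 65000 nM.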

Compound 4, half-maximal cytotoxic concentration: 69400 nM
Compound 4: the middle estimate sits 2.3-fold (0.36 log units) below what was measured; the whole stated range lies below it.
By their numbers in this assay, from the lowest: compound 3; then compounds 2, 4 and 1 (each within the scatter of the next, the first and the last beyond it).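

In this assay the change from methoxy to propoxy proves larger than its size might suggest: ethyl in place of hydrogen on a saturated chain carbon bound to an oxygen on an aromatic ring gives a 4.4-fold higher number from compound 3 to compound 4 (0.64 log units; beyond the scatter) and so already brings the number up to the level of the larger groups. Compound 4 cannot be told apart from either of them, with a 1.7-fold higher number from compound 2 to compound 4 (0.22 log units; within the scatter) on one side and a 1.6-fold lower number from compound 1 to compound 4 (0.21 log units; within the scatter) on the other, and both of these steps lie within the scatter. At this position the four compounds therefore show methoxy set apart from the three larger groups, although a 2.7-fold lower number from compound 1 to compound 2 (0.43 log units; beyond the scatter) still keeps those two compounds apart from each other.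

Going by these compounds, whether the number holds at this level with a longer chain such as octyl, or shifts when the chain ends in an amine or a carboxylic acid, remains open. Nothing at hand explains why so short an addition moves the number this far.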